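The source may report more compounds than this note shows. Statements on the series, on what has been measured and on what is new or still open speak of the compounds shown alone.

Of the compounds shown here, three from this series have been measured in a functional assay on SK-OV-3 cells (Homo sapiens) for cytotoxicity, read by MTT assay, with a stated time of 2 days (on this read-out higher numbers stand for weaker inhibition and lower numbers for stronger inhibition), and a fourth awaits its number. Compound 1 `Cc1ccc(CO/N=C2/C(c3c[nH]c4ccccc34)=Nc3ccccc32)cc1` gives 32400 nM. Compound 3 `FC(F)(F)c1ccc(CO/N=C2/C(c3c[nH]c4ccccc34)=Nc3ccccc32)cc1` gives 24200 nM and differs from compound 1 in one place only: trifluoromethyl in place of methyl on an aromatic carbon That change made a 1.3-fold lower number from compound 1 to compound 3 (0.13 log units; within the scatter), so the two numbers cannot be told apart with confidence.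

Compound 2 `Cc1ccc(CO/N=C2/C(c3c[nH]c4ccc(Br)cc34)=Nc3ccc(Br)cc32)cc1` gives 7220 nM, the lowest of the three numbers, and its gaps to both compound 1 and compound 3 lie beyond the scatter. How the core of compound 2 differs from the core of compound 1 is not broken down here.

Compound 4 `FC(F)(F)c1ccc(CO/N=C2/C(c3c[nH]c4ccc(Br)cc34)=Nc3ccc(Br)cc32)cc1` stands to compound 2 as compound 3 stands to compound 1: trifluoromethyl in place of methyl on an aromatic carbon The place of the change reads the same in both pairs, so this is the same change. Since the earlier step was within the scatter, a similarly small move is expected. For compound 4 the expected step is a 1.3-fold lower number from compound 2 to compound 4 (0.11 log units; within the scatter). Compound 4 is accordingly estimated at 5600 nM, with a likely range from 2500 nM to 13000 nM.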

Compound 4, half-maximal inhibitory concentration: 10200 nM
Compound 4: the middle estimate sits 1.8-fold (0.26 log units) below what was measured; the measured number falls inside the stated range.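

On the second core, putting trifluoromethyl in place of methyl gives a 1.4-fold higher number from compound 2 to compound 4 (0.15 log units; within the scatter), so in this assay the two numbers cannot be told apart. Set beside the earlier step, the change behaves alike on both cores, with no step large enough to read and no difference between the steps that can be told from scatter: the same change on two cores in this assay, a 1.3-fold lower number (0.13 log units; within the scatter) from compound 1 to compound 3 and a 1.4-fold higher number (0.15 log units; within the scatter) from compound 2 to compound 4, 1.9-fold (0.28 log units) apart, within the scatter of two such steps. This shows that, for these two pairs, the swap carries over as a change too small to detect, but the opposite directions of the two steps mean nothing, and two pairs in one assay do not show that it would stay this small on any other core.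

Still open, as far as these compounds go, is what a different group would do in the same place on the benzyl ring, such as an amine, a carboxylic acid or a longer chain like butyl. Also open, from the compounds shown here alone, is how much each of the two bromine atoms in compound 2 and compound 4 contributes on its own.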